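The compounds below may be only part of what the source reports. "The series", "measured", "known", "first", "only" and "open" are said of these compounds alone.

Measured in a functional assay on BT-549 cells (Homo sapiens) for inhibition, read by sulforhodamine B assay, with a stated time of 48 h, tested at 10 uM; on this read-out lower numbers stand for less inhibition and higher numbers for more inhibition at the one concentration tested (going by the name of the read-out):
compound 1 `c1ccc(-c2cn3ccnc3c(-c3ccc4ncn(C5CCCCC5)c4c3)n2)cc1`: 57.1%
compound 2 `CC(=O)c1ccc(-c2cn3ccnc3c(-c3ccc4ncn(C5CCCCC5)c4c3)n2)cc1`: 4.68%
compound 3 `Brc1ccc(-c2cn3ccnc3c(-c3ccc4ncn(C5CCCCC5)c4c3)n2)cc1`: 35.1%

Compound 3 stands second highest of the three numbers. Its nearest neighbour is compound 1, the step of a number 22 percentage points lower from compound 1 to compound 3 (beyond the scatter) being modest and beyond the scatter; its furthest is compound 2, the step of a number 30.4 percentage points higher from compound 2 to compound 3 (beyond the scatter) being large. Compound 4 `Fc1ccccc1-c1cn2ccnc2c(-c2ccc3ncn(C4CCCCC4)c3c2)n1` is not yet measured. It differs from compound 3 in one place: 2-fluorophenyl in place of 4-bromophenyl on an aromatic carbon. Going by the values given here, no measured step exchanges one halogen-bearing phenyl for another; the only step touching this ring's halogen is a number 22 percentage points lower from compound 1 to compound 3 (beyond the scatter), hydrogen traded for bromo. Because a number 22 percentage points lower from compound 1 to compound 3 (beyond the scatter) was only modest, a step no larger than that, upward, is expected for compound 4: a number 9.9 percentage points higher from compound 3 to compound 4 (within the scatter). In this assay compound 4 is therefore estimated at 45%, range 20% to 70%.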

Compound 4, a percentage reported as inhibition, at one concentration (the size of the read-out at that concentration, not a potency): 4.08%
Compound 4: middle estimate off by 40.9 percentage points, on the high side, and the stated range ends above it.
By their numbers in this assay, from the lowest: compounds 4 and 2 (each within the scatter of the next); then compound 3; then compound 1.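

In this assay, a halogen on this phenyl does not in itself keep the number up: 2-fluorophenyl falls well short of 4-bromophenyl (a number 31 percentage points lower from compound 3 to compound 4 (beyond the scatter)) and of the unsubstituted phenyl (a number 53 percentage points lower from compound 1 to compound 4 (beyond the scatter)). All three substituents shown now lower the number from compound 1, and 2-fluorophenyl cannot be told apart from 4-acetylphenyl (a number 0.6 percentage points lower from compound 2 to compound 4 (within the scatter)). Nothing available explains these steps.

As far as these compounds go, whether the drop follows the fluoro or its ring position stays open, as both change together. From the compounds shown here alone, how an amine or a carboxylic acid on this phenyl would read is also open.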